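The source may hold more compounds than are shown below. What is called first, only, known or untested is meant among the compounds shown, and "the series" means these compounds.

Measured so far in an assay for binding affinity to Adrenergic receptor alpha-1 (Rattus norvegicus); on this read-out lower numbers stand for stronger inhibition and higher numbers for weaker inhibition:
compound 1 `COc1ccccc1N1CCN(CCCn2c(=O)[nH]c3cc[nH]c3c2=O)CC1` gives 28 nM;
compound 2 `O=c1[nH]c2cc[nH]c2c(=O)n1CCCN1CCN(c2ccccc2Cl)CC1` gives 59.8 nM;
compound 3 `O=c1[nH]c2cc(-c3ccccc3)[nH]c2c(=O)n1CCN1CCN(c2ccccc2Cl)CC1` gives 1.08 nM.

Compound 2 stands highest of these three numbers, with compound 1 nearest. Going by the values given here, the one step that changes a single place, a 2.1-fold higher number from compound 1 to compound 2 (0.33 log units; beyond the scatter), is modest and concerns a different part of the molecule. Compound 4 `O=c1[nH]c2cc(-c3ccccc3)[nH]c2c(=O)n1CCCN1CCN(c2ccccc2Cl)CC1` differs from compound 2 by phenyl in place of hydrogen on an aromatic carbon. Among the compounds with values here, no measured step isolates this change: compound 3 carries the same phenyl but also a shorter chain, so its two changes cannot be separated. Within the data shown here, still, compound 3 gives 1.08 nM, far below compound 2, and nothing among the measured compounds points the other way, so a large step downward is expected. Compound 4 is therefore expected to reach 3 nM, with a range from 0.8 nM to 12 nM, meaning an expected step of a 20-fold lower number from compound 2 to compound 4 (1.30 log units; beyond the scatter).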

Compound 4, inhibition constant: 62.4 nM
Compound 4: middle estimate off by 21-fold (1.32 log units), on the low side; the whole stated range lies below it.
By their numbers in this assay, from the lowest: compound 3; then compound 1; then compounds 2 and 4 (each within the scatter of the next).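

Putting phenyl in place of hydrogen on this aromatic carbon, next to the ring nitrogen, gives a 1.0-fold higher number from compound 2 to compound 4 (0.02 log units; within the scatter), so on this chain the added ring makes no readable difference in this assay. Compound 3, with the same phenyl on a shorter chain, gives 1.08 nM, whereas compound 4 gives 62.4 nM, so phenyl alone does not account for the low number of compound 3. No supporting measurement explains this result.

Open, as far as these compounds go, is what phenyl does on the shorter chain. Also open, from the compounds shown here alone, is whether an amine or a carboxylic acid at this position would match phenyl here.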